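Para-substituent variation on an aryl core: cytotoxicity notes

The source may hold more compounds than are shown below. What is called first, only, known or untested is meant among the compounds shown, and "the series" means these compounds.

Measured compounds:
compound 1, `CCOC(=O)C12C(=O)OCC=C1COC2c1ccccc1`, 12800 nM
compound 2, `CCOC(=O)C12C(=O)OCC=C1COC2c1ccc(F)cc1`, 22900 nM
compound 3, `CCOC(=O)C12C(=O)OCC=C1COC2c1ccc(C(C)(C)C)cc1`, 25400 nM

In a functional assay on HeLa cells (Homo sapiens) for cytotoxicity, read by MTT assay (on this read-out higher numbers stand for weaker inhibition and lower numbers for stronger inhibition), compound 3 gives the highest of the three numbers, but its separation from the others is small: a 2.0-fold higher number from compound 1 to compound 3 (0.30 log units; within the scatter) and a 1.1-fold higher number from compound 2 to compound 3 (0.04 log units; within the scatter) both sit within the scatter, as does a 1.8-fold higher number from compound 1 to compound 2 (0.25 log units; within the scatter). Compound 4, `CCOC(=O)C12C(=O)OCC=C1COC2c1ccc(N(C)C)cc1`, carries the change (dimethylamino in place of tert-butyl on an aromatic carbon). Every exchange tried so far on this aromatic carbon, hydrogen to fluoro, hydrogen to tert-butyl and fluoro to tert-butyl, has left the number within the scatter, so no step beyond it is expected for dimethylamino either. For compound 4 the estimate is 20000 nM (range 7000 nM to 60000 nM), which means an expected step of a 1.3-fold lower number from compound 3 to compound 4 (0.10 log units; within the scatter).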

Compound 4, half-maximal inhibitory concentration: 23400 nM
For compound 4 the middle estimate is 1.2-fold (0.07 log units) below the measured one; the measured number falls inside the stated range.
By their numbers in this assay, from the lowest: compounds 1, 2, 4 and 3 (each within the scatter of the next).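

In this assay, dimethylamino on this aromatic carbon stays within the scatter of hydrogen (a 1.8-fold higher number from compound 1 to compound 4 (0.26 log units; within the scatter)), fluoro (a 1.0-fold higher number from compound 2 to compound 4 (0.01 log units; within the scatter)) and tert-butyl (a 1.1-fold lower number from compound 3 to compound 4 (0.04 log units; within the scatter)). The series now shows that a nitrogen-bearing group with 1 hydrogen-bond acceptor, entering in place of all-carbon tert-butyl, also leaves the number within the scatter. No supporting data bear on this result.

As far as these compounds go, whether a carboxylic acid or a primary amine on this carbon would move the number beyond the scatter remains open. So does the response to changes elsewhere on the shared core.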